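This account rests on a few compounds, and the source may have more. Where it says the series, first, only, none or still open, it means among the compounds named here.

Measured compounds:
compound 1 `O=C(Nc1ccc(S(=O)(=O)Nc2ccccc2)cc1)c1cc(F)c(Cl)cc1F` — 141 nM
compound 2 `O=C(NS(=O)(=O)c1ccc(NC(=O)c2ccc(Cl)cc2Cl)cc1)c1ccccc1` — > 100000 nM

In a functional assay on HEK293 cells for agonist activity at probable G-protein coupled receptor 27 (Homo sapiens), read by a luciferase reporter and beta-arrestin recruitment, with a stated time of 10 min (on this read-out lower numbers stand for an effect already at smaller amounts and higher numbers for an effect only at larger amounts of compound), compound 2 gives > 100000 nM, which is a limit of the assay and not a number, so compound 2 stands at the weak end of the two values shown (the limit of > 100000 nM in this assay, at which 1 of the 2 values shown sits). Compound 3 `CN(c1ccccc1)S(=O)(=O)c1ccc(NC(=O)c2ccc(Cl)cc2Cl)cc1` differs from compound 2 by methyl(phenyl)amino in place of benzamido on a sulfonyl sulfur. Within the data shown here, no measured pair shows this change. Because compound 1, a sulfonamide with no acyl group on its nitrogen, gives 141 nM in this assay, compound 3 is expected to move toward smaller amounts, a step of an at least 50-fold lower number from compound 2 to compound 3 (1.69 log units; beyond the scatter). Compound 3 is estimated at 2000 nM, between 200 nM and 30000 nM.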

Compound 3, half-maximal effective concentration: 2570 nM
Beside the measured number, compound 3's estimate is 1.3-fold (0.11 log units) below it; measured number inside the range.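

In this assay, putting methyl(phenyl)amino in place of benzamido on a sulfonyl sulfur gives an at least 38-fold lower number from compound 2 to compound 3 (1.59 log units; beyond the scatter), the first step read at this place. A measurable effect therefore appears with a group that has no hydrogen-bond donor or acceptor by the count of the two groups. Compound 2 sits at a limit of the assay and not at a number, so the full size of this step stays unknown: the limit of > 100000 nM in this assay, at which 1 of the 3 values shown sits.

The compounds shown leave open what the methyl group alone contributes, with compound 1 differing from compound 3 in more than one place. As far as these compounds go, whether a plain amino group or a morpholine on the sulfonyl sulfur would carry this effect is also open.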